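The source may report more compounds than this note shows. Statements on the series, on what has been measured and on what is new or still open speak of the compounds shown alone.

Working notes on the series. Of the compounds shown here, three have so far been measured in a functional assay on Fem-X cells (Homo sapiens) for cytotoxicity, read by MTT assay, with a stated time of 72 h; a lower number here means a stronger inhibitor, a higher number a weaker inhibitor. Compound 1 `CC(C)(C)C1=CC(=O)C=C(NCC(=O)O)C1=O` gives 34300 nM. Compound 3 `CC1=CCC[C@H]2[C@](C)(CC3=CC(=O)C=C(NCC(=O)O)C3=O)[C@@H](C)CC[C@]12C` gives 17800 nM, and compound 2 `CC1=CCC[C@H]2[C@](C)(CC3=CC(=O)C=C(N[C@@H](CC(C)C)C(=O)O)C3=O)[C@@H](C)CC[C@]12C` gives 10900 nM. Compound 2 and compound 3 share a core and differ only by isobutyl in place of hydrogen on a saturated chain carbon bound to an amine nitrogen and a carbonyl carbon; the step of a 1.6-fold lower number from compound 3 to compound 2 (0.21 log units; within the scatter). How the core of compound 1 differs from the core of compound 3 is not broken down here; the two values for compound 1 and compound 3 lie within the scatter of each other, so nothing is read from that pair.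

Compound 4 `CC(C)C[C@H](NC1=CC(=O)C=C(C(C)(C)C)C1=O)C(=O)O` awaits measurement. It differs from compound 1 by isobutyl in place of hydrogen on a saturated chain carbon bound to an amine nitrogen and a carbonyl carbon, the same change as from compound 3 to compound 2, made at the same place in both pairs. Since the earlier step of a 1.6-fold lower number from compound 3 to compound 2 (0.21 log units; within the scatter) stayed within the scatter, a step of about the same size is expected here, a 1.6-fold lower number from compound 1 to compound 4 (0.21 log units; within the scatter), resting on that one earlier pair alone. Compound 4 is therefore estimated at 21000 nM, with a likely range from 9000 nM to 50000 nM.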

Compound 4, half-maximal inhibitory concentration: 39400 nM
The estimate for compound 4 lay 1.9-fold (0.27 log units) below the measured number; the range from low to high includes it.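

In this assay, isobutyl in place of hydrogen on a saturated chain carbon bound to an amine nitrogen and a carbonyl carbon gives a 1.1-fold higher number from compound 1 to compound 4 (0.06 log units; within the scatter). Set beside the earlier pair, the change shows no difference between the two cores that can be told apart from the scatter: the same change on two cores in this assay, a 1.6-fold lower number (0.21 log units; within the scatter) from compound 3 to compound 2 and a 1.1-fold higher number (0.06 log units; within the scatter) from compound 1 to compound 4, 1.9-fold (0.27 log units) apart, within the scatter of two such steps. Among these compounds, this shows only that the change leaves the number within the scatter on both cores; it does not show that isobutyl has a real effect on either core, and two small steps give no rule for carrying the change to any further core.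

On these data alone, whether another group on that saturated chain carbon, such as benzyl, hydroxymethyl or a longer chain, would give a step beyond the scatter remains open. Also open, as far as these compounds go, is how the numbers would respond if a methyl ester or a primary amide stood in place of the carboxylic acid.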